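Trading Benzyl for Methyl at Selenium

This account rests on a few compounds, and the source may have more. Where it says the series, first, only, none or still open, it means among the compounds named here.

Four compounds share a pattern in which a selenium atom carries either a benzyl or a methyl group, and they were tested in a functional assay on MCF7 cells (Homo sapiens) for cytotoxicity, read by MTT assay, with a stated time of 72 h; on this read-out higher numbers stand for weaker inhibition of growth and lower numbers for stronger inhibition of growth. Compound 1 `C[Se]/C(=N\C(=O)c1cccs1)NC(=O)c1cccs1` gives 5640 nM in this assay. Compound 3 `O=C(/N=C(/NC(=O)c1cccs1)[Se]Cc1ccccc1)c1cccs1` is reported in this assay only as a limit of the measurement, > 100000 nM. The change from compound 3 to compound 1 is hydrogen in place of phenyl on a saturated chain carbon bound to a selenium atom, and it produces an at least 17-fold lower number from compound 3 to compound 1 (1.24 log units; beyond the scatter).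

Compound 2 `O=C(/N=C(/NC(=O)c1ccno1)[Se]Cc1ccccc1)c1ccno1` likewise appears in this assay only as a limit, > 100000 nM. How the core of compound 2 differs from that of compound 3 is not broken down here. Going by the values given here, compound 4 `C[Se]/C(=N\C(=O)c1ccno1)NC(=O)c1ccno1` is the counterpart to compound 2 that is still to be measured; the change from compound 2 to compound 4 is hydrogen in place of phenyl on a saturated chain carbon bound to a selenium atom, which is the same change as the one from compound 3 to compound 1, made at the same place.

On the basis of that earlier step, the expected step from compound 2 to compound 4 in this assay is an at least 6.6-fold lower number from compound 2 to compound 4 (0.82 log units; beyond the scatter). Its size can only be stated as a lower bound, because the limit of > 100000 nM in this assay, at which 2 of the 3 values shown sit, means the starting point for compound 2 is itself unknown. Taking compound 1 as the nearest guide, compound 4 is estimated to give about 15000 nM in this assay, with a plausible range from 3000 nM to 100000 nM.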

Compound 4, concentration for total growth inhibition: 57500 nM
Compound 4: middle estimate off by 3.8-fold (0.58 log units), on the low side, within the range that was stated.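

On the core of compound 4, trading benzyl for methyl at selenium gives an at least 1.7-fold lower number from compound 2 to compound 4 (0.24 log units; that floor lies within the scatter) in this assay, and a floor of this size neither establishes a real drop on this core nor rules out a large one. The second core therefore does not go against the first, but it does not confirm that the change carries over with the same size: the same change on two cores in this assay, an at least 17-fold lower number (1.24 log units; beyond the scatter) from compound 3 to compound 1 and an at least 1.7-fold lower number (0.24 log units; that floor lies within the scatter) from compound 2 to compound 4; the limit leaves it open whether they differ Neither step has a known full size, as the benzyl compounds supply no exact starting number: the limit of > 100000 nM in this assay, at which 2 of the 4 values shown sit.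

The compounds shown place only benzyl and methyl on selenium, so they leave open how a longer chain such as ethyl, or a chain ending in an amine or a carboxylic acid, would read in this assay. On these data alone, the true numbers of compound 2 and compound 3 also remain open, and with them the answer to whether the change from benzyl to methyl is worth the same on both cores.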